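This account rests on a few compounds, and the source may have more. Where it says the series, first, only, none or still open, it means among the compounds named here.

In an ADME assay on NIH3T3 cells (Mus musculus) for cytotoxicity, read by MTT assay, with a stated time of 24 h (a lower number here means a stronger inhibitor, a higher number a weaker inhibitor), three compounds built on one shared core have been measured. Compound 1 `O=C(CSc1ncccn1)N/N=c1/scc(-c2ccc(Br)cc2)n1-c1ccccc1` gives 273 ug/mL. Compound 3 `COc1ccc(-c2cs/c(=N/NC(=O)CSc3ncccn3)n2-c2ccccc2)cc1` gives 450 ug/mL. Compound 2 `O=C(CSc1ncccn1)N/N=c1/scc(-c2ccc(F)cc2)n1-c1ccccc1` gives only a limit of this assay, > 500 ug/mL, so its number is known as a bound and not as a value. That bound is the limit of > 500 ug/mL in this assay, at which 1 of the 3 values shown sits. The measured steps of an at least 1.8-fold higher number from compound 1 to compound 2 (0.26 log units; that floor lies within the scatter), a 1.6-fold higher number from compound 1 to compound 3 (0.22 log units; within the scatter) and an at least 1.1-fold lower number from compound 2 to compound 3 (0.04 log units; that floor lies within the scatter) all swap the group on an aromatic carbon of the core, and each of them stays within the scatter.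

Compound 4 `O=C(CSc1nnnn1-c1ccccc1)N/N=c1/scc(-c2ccc(F)cc2)n1-c1ccccc1` has not yet been measured in this assay. It differs from compound 2 at a different place: 1-phenyl-1H-tetrazol-5-yl in place of pyrimidin-2-yl on a sulfur. Within the data shown here, none of the measured steps touches the sulfur or the group attached to it, so no measured step bears directly on this change, and there is no ground in the data for expecting a step beyond the scatter in either direction. Compound 4 is therefore expected to give about 500 ug/mL, with a range from 250 ug/mL to 1000 ug/mL. The expected step is a number no higher from compound 2 to compound 4 (the limit leaves the size open), and a reading that again ends as a limit rather than a number is likely.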

Compound 4, half-maximal inhibitory concentration: 207 ug/mL
Estimate against measurement, compound 4: 2.4-fold (0.38 log units) above, and the stated range ends above it.
By their numbers in this assay, from the lowest: compounds 4, 1 and 3 (each within the scatter of the next, the first and the last beyond it). At a limit, above all of these: compound 2.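

Among these compounds, changing the group on the sulfur gives the first step in this set that lies beyond the scatter in this assay: with 1-phenyl-1H-tetrazol-5-yl in place of pyrimidin-2-yl, there is an at least 2.4-fold lower number from compound 2 to compound 4 (0.38 log units; beyond the scatter). Among the compounds shown here, the swaps on the aromatic carbon all stayed within the scatter, so this single pair is the only evidence here that a change to the shared core's substituents can clearly move the number, and it moves it towards stronger inhibition of the cells. From the compounds shown here alone, the full size of the step stays unknown, since compound 2 gives only a limit of the assay and not a number: the limit of > 500 ug/mL in this assay, at which 1 of the 4 values shown sits.

The entering group brings a five-membered aromatic ring and a six-membered carbon ring together, so this one pair cannot say which of the two goes with the lower number. The compounds shown also leave open how a plain methyl group or a carboxylic acid on the same sulfur would read, and whether this swap would give a similar step with bromo or methoxy in place of fluoro on the aromatic carbon.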